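Notes on the cyclopentyl-to-cyclopentenyl step in the triazolopyrimidine series

This account rests on a few compounds, and the source may have more. Where it says the series, first, only, none or still open, it means among the compounds named here.

Measured so far:
compound 1 `CCCSc1nc(N[C@@H]2C[C@H]2c2scnc2C)c2nnn([C@@H]3C[C@H](OCCO)[C@@H](O)[C@H]3O)c2n1` – 1810 nM
compound 2 `CCCSc1nc(N[C@@H]2C[C@H]2c2cccnc2)c2nnn([C@@H]3C[C@H](OCCO)[C@@H](O)[C@H]3O)c2n1` – 1520 nM
compound 3 `CCCSc1nc(N[C@@H]2C[C@H]2c2ccc(F)c(F)c2)c2nnn([C@H]3[C@H](O)[C@H](O)[C@@H](OCCO)[C@@H]3O)c2n1` – 1380 nM

All three numbers come from an assay on a cell-free system (plasma) for antagonist activity at P2Y purinoceptor 12 (Rattus norvegicus), with a stated time of 5 min; a higher number here means a weaker inhibitor, a lower number a stronger inhibitor. Compound 3 holds the lowest of the three numbers, but its gap to compound 2 and to compound 1 is within the scatter, so no ranking among the three is supported. For the measured compounds named here, the only step between compounds differing in one place, a 1.2-fold lower number from compound 1 to compound 2 (0.08 log units; within the scatter), concerns the aromatic group on the cyclopropane and is itself within the scatter.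

Compound 4 `CCCSc1nc(N[C@@H]2C[C@H]2c2ccc(F)c(F)c2)c2nnn([C@@H]3C=C[C@@H](O)[C@H]3O)c2n1` differs from compound 3 in a different place: 4,5-dihydroxycyclopent-2-en-1-yl in place of 2,4,5-trihydroxy-3-(2-hydroxyethoxy)cyclopentyl on an aromatic nitrogen. Going by the values given here, no measured step in this assay touches this part of the molecule, so nothing measured bears directly on the change. The cyclopropylamine portion and the propylthio group are unchanged between compound 3 and compound 4. Removal of the hydroxyethoxy chain and one hydroxyl, with the new double bond in the five-membered ring, leaves the expected direction open, and the width of the estimate reflects that.

For compound 4 the expected value in this assay is 2500 nM, with a range of 700 nM to 9000 nM, meaning an expected step of a 1.8-fold higher number from compound 3 to compound 4 (0.26 log units; within the scatter).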

Compound 4, half-maximal inhibitory concentration: 850 nM
The estimate for compound 4 lay 2.9-fold (0.47 log units) above the measured number; low and high end bracket the measured number.
By their numbers in this assay, from the lowest: compounds 4, 3, 2 and 1 (each within the scatter of the next, the first and the last beyond it).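

In this assay, for the compounds shown here, the substituent on the aromatic nitrogen changes for the first time in this set, whereas the earlier single-place step concerned only the aromatic group on the cyclopropane. The step of a 1.6-fold lower number from compound 3 to compound 4 (0.21 log units; within the scatter) shows that this position accepts 4,5-dihydroxycyclopent-2-en-1-yl in place of 2,4,5-trihydroxy-3-(2-hydroxyethoxy)cyclopentyl with no change beyond the scatter, even though the entering group has fewer heavy atoms, hydrogen-bond donors and acceptors, and defined stereocentres, so the full hydroxyethoxy-bearing group is not required for a value in this range here. No supporting measurement is available to account for this result.

The step combines the loss of the 2-hydroxyethoxy chain, the loss of a ring hydroxyl and the gain of the ring double bond, so the compounds shown cannot assign any share of it to one of these changes, and a saturated dihydroxycyclopentyl group at this position would be needed to separate the double bond from the rest. Also open, from the compounds shown here alone, is how the position responds to a group of another kind, such as an amine or a carboxylic acid on the five-membered ring in place of the hydroxyl groups.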